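The source may hold more compounds than are shown below. What is called first, only, known or untested is meant among the compounds shown, and "the series" means these compounds.

In an ADME assay on NIH3T3 cells (Mus musculus) for cytotoxicity, read by MTT assay, with a stated time of 24 h (on this read-out higher numbers stand for weaker inhibition and lower numbers for stronger inhibition), compound 3 `O=C(CN1CCN(c2ccccc2Cl)CC1)N1CCN(c2nnc(-c3ccc(Cl)cc3)c(-c3ccc(Cl)cc3)n2)CC1` gives only a limit of the assay, > 803000 nM, and not a number. Compound 1 `O=C(CN1CCN(c2ccccc2)CC1)N1CCN(c2nnc(-c3ccc(Cl)cc3)c(-c3ccc(Cl)cc3)n2)CC1` likewise reaches only a limit, > 850000 nM. Among the measured compounds shown here, compound 2 `COc1ccccc1N1CCN(CC(=O)N2CCN(c3nnc(-c4ccc(Cl)cc4)c(-c4ccc(Cl)cc4)n3)CC2)CC1` is the one member of the set with a measured number, 405000 nM. The step from compound 1 to compound 2 is an at least 2.0-fold lower number from compound 1 to compound 2 (0.32 log units; beyond the scatter), and the step from compound 2 to compound 3 is an at least 1.9-fold higher number from compound 2 to compound 3 (0.29 log units; that floor lies within the scatter); the step from compound 1 to compound 3 is a step that the two limits leave unreadable from compound 1 to compound 3 because the limit of > 850000 nM in this assay, at which 1 of the 3 values shown sits, and the limit of > 803000 nM in this assay, at which 1 of the 3 values shown sits, cap both ends of it.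

Compound 4 `COc1cccc(N2CCN(CC(=O)N3CCN(c4nnc(-c5ccc(Cl)cc5)c(-c5ccc(Cl)cc5)n4)CC3)CC2)c1` has not yet been measured. It differs from compound 3 by one change, (3-methoxyphenyl in place of 2-chlorophenyl on an amine nitrogen in a ring). For the measured compounds named here, the steps that bear on it are the methoxy-for-hydrogen step from compound 1 to compound 2, which gave a lower number, and the chloro-for-methoxy step from compound 2 to compound 3, which gave a higher number with a floor inside the scatter. Since compound 4 carries a methoxy group as compound 2 does, the expectation is a number near that of compound 2, that is an expected step of an at least 1.7-fold lower number from compound 3 to compound 4 (0.25 log units; that floor lies within the scatter) from compound 3 to compound 4. Compound 4 is estimated at 450000 nM, in a range from 200000 nM to 900000 nM.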

Compound 4, half-maximal inhibitory concentration: 202000 nM
The estimate for compound 4 lay 2.2-fold (0.35 log units) above the measured number, within the range that was stated.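

In this assay, the 3-methoxyphenyl group in place of the 2-methoxyphenyl group gives (a 2.0-fold lower number from compound 2 to compound 4 (0.30 log units; within the scatter)), so the two places of the methoxy group cannot be told apart here. Among the compounds shown here, the methoxy group at its new place also gives a step from the compound that carries only hydrogen (an at least 4.2-fold lower number from compound 1 to compound 4 (0.62 log units; beyond the scatter)) and a step from the chloro compound (an at least 3.9-fold lower number from compound 3 to compound 4 (0.59 log units; beyond the scatter)); both floors lie beyond the scatter, whereas the earlier step from compound 2 to compound 3 had a floor inside it, so the gap between methoxy and chloro now reads clearly for the first time. Compound 3 gives only a limit of the assay, so its step has a floor and no exact size: (the limit of > 803000 nM in this assay, at which 1 of the 4 values shown sits).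

Compound 1 also gives only a limit of the assay, which leaves the true size of its step open too: (the limit of > 850000 nM in this assay, at which 1 of the 4 values shown sits). The compounds shown also leave open how a longer chain such as ethoxy, or an amine or a carboxylic acid, would read on this phenyl ring in this assay and whether any such group would follow the two methoxy compounds.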